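This account rests on a few compounds, and the source may have more. Where it says the series, first, only, none or still open, it means among the compounds named here.

Working notes on the series, read in a functional assay on MCF7 cells (Homo sapiens) for antiproliferative activity, read by MTT assay, with a stated time of 48 h; a higher number here means a weaker inhibitor, a lower number a stronger inhibitor. Compound 1 `O=c1cc(-n2cc(COc3ccccc3)nn2)c2cc(Br)ccc2o1`, which carries a plain phenyl on the oxygen, gives 1720 nM. Compound 2 `O=c1cc(-n2cc(COc3cccnc3)nn2)c2cc(Br)ccc2o1` gives 39800 nM, and compound 3 `O=c1cc(-n2cc(COc3ccccc3O)nn2)c2cc(Br)ccc2o1` gives 24800 nM. The three numbers fall on two levels, with compound 3 on the upper level together with compound 2. The gap within that level is small: a 1.6-fold lower number from compound 2 to compound 3 (0.21 log units; within the scatter). Compound 1 stands alone on the lower level.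

Compound 4 `Nc1ccc(OCc2cn(-c3cc(=O)oc4ccc(Br)cc34)nn2)cc1` keeps the shared core and changes only the aryl group, with 4-aminophenyl in place of 2-hydroxyphenyl on an oxygen on a saturated carbon.

Within the data shown here, two measured steps bear on this change, and both start from the plain phenyl: a 14-fold higher number from compound 1 to compound 3 (1.16 log units; beyond the scatter) and a 23-fold higher number from compound 1 to compound 2 (1.36 log units; beyond the scatter). Both departures from phenyl raised the number by a large step in this assay, and neither compound goes against that within these three. Among the measured compounds shown here, compound 4 is a further departure from phenyl, yet no measured compound carries an amino group. Only a partial return toward compound 1 is therefore expected, a modest move to a lower number. The estimated step is a 2.5-fold lower number from compound 3 to compound 4 (0.39 log units; beyond the scatter). For compound 4 the expected value is 10000 nM, with an estimated range of 2500 nM to 38000 nM.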

Compound 4, half-maximal inhibitory concentration: 2040 nM
Compound 4: the middle estimate sits 4.9-fold (0.69 log units) above what was measured, and the stated range ends above it.
By their numbers in this assay, from the lowest: compounds 1 and 4 (each within the scatter of the next); then compounds 3 and 2 (each within the scatter of the next).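

At this place, on an oxygen on a saturated carbon, a substituent on the phenyl does not by itself raise the number: amino in place of hydrogen on an aromatic carbon gives a 1.2-fold higher number from compound 1 to compound 4 (0.07 log units; within the scatter) in this assay, so compound 4 stands level with compound 1. The steps from the upper level are large, a 12-fold lower number from compound 3 to compound 4 (1.08 log units; beyond the scatter) and a 20-fold lower number from compound 2 to compound 4 (1.29 log units; beyond the scatter), and the series now divides into two levels of two compounds each, with compound 1 and compound 4 on the lower level. The exchange of 2-hydroxyphenyl for 4-aminophenyl leaves the heavy-atom, hydrogen-bond donor and hydrogen-bond acceptor counts matched, so these counts do not separate the two levels.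

No measurement on hand accounts for the gap between these aryl groups.

The compounds shown also cannot separate the identity of the substituent from its place on the phenyl, as 2-hydroxyphenyl and 4-aminophenyl differ in both, which leaves open how 4-hydroxyphenyl, 2-aminophenyl or a phenyl bearing a carboxylic acid would read in this assay.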